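This account rests on a few compounds, and the source may have more. Where it says the series, first, only, none or still open, it means among the compounds named here.

Compound 1 `CCCCCNC(=O)n1cc(-c2ccccc2)oc1=O`: < 0.0834 h, a limit
Compound 2 `CCOCCNC(=O)n1cc(-c2ccccc2)oc1=O`: < 0.0834 h, a limit
Compound 3 `COc1cccc(-c2cn(C(=O)NCCCCc3ccccc3)c(=O)o2)c1`: 0.5 h

Among the compounds with values here, in an ADME assay on microsomes from liver (Mus musculus) for metabolic stability, read by LC-MS, using NADPH, tested at 4.6 uM (a higher number here means that the compound lasts longer, a lower number that the compound disappears faster), compound 3 stands at 0.5 h, the only true number of the three. The other two values are limits, as the limit of < 0.0834 h in this assay, at which 2 of the 3 values shown sit, records. Compound 4 `O=C(NCCCCc1ccccc1)n1cc(-c2cccnc2)oc1=O` carries pyridin-3-yl in place of 3-methoxyphenyl on an aromatic carbon. Within the data shown here, the sole measured step, a step that the two limits leave unreadable from compound 1 to compound 2, lies on the chain, not at this place, so it offers no guide to size. The expectation therefore rests on compound 3 at 0.5 h, with no step beyond the scatter foreseen in this assay. The expected change is a 1.3-fold lower number from compound 3 to compound 4 (0.10 log units; within the scatter). For compound 4 the estimated half-life is 0.4 h, with an expected range of 0.12 h to 1.2 h.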

Compound 4, half-life: > 1 h
Compound 4 ended at the assay's limit (the forecaster's own chance of this, stated with the estimate: 15%); at least 2.5-fold (0.39 log units) between middle value and limit.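

In this assay, the place next to the ring oxygen gives its first readable step, as pyridin-3-yl in place of 3-methoxyphenyl brings an at least 2.0-fold higher number from compound 3 to compound 4 (0.30 log units; that floor lies within the scatter). Compound 4 carries a limit, not a number: the limit of > 1 h in this assay, at which 1 of the 4 values shown sits. From the compounds shown here alone, the step is therefore only a floor, and its true size stays unknown.

The compounds shown leave open whether pyridin-3-yl would have the same effect on the chains of compound 1 and compound 2. They also leave open how the half-life would respond to an amine or a carboxylic acid on the pyridin-3-yl.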